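Bromo for isopropyl, carried from one core to its isomer

This account rests on a few compounds, and the source may have more. Where it says the series, first, only, none or still open, it means among the compounds named here.

Measured compounds:
compound 1, `CC(C)c1ccc(-n2cc(-c3cn([C@H]4C[C@H](O)[C@@H](CO)O4)c(=O)[nH]c3=O)nn2)cc1`: 29000 nM
compound 2, `O=c1[nH]c(=O)n([C@H]2C[C@H](O)[C@@H](CO)O2)cc1-c1cn(-c2ccc(Br)cc2)nn1`: 4600 nM
compound 3, `CC(C)c1ccc(-n2nncc2-c2cn([C@H]3C[C@H](O)[C@@H](CO)O3)c(=O)[nH]c2=O)cc1`: > 200000 nM

The three measured compounds were tested in an ADME assay on L1210 cells (Mus musculus) for cytotoxicity, read by cell counting, with a stated time of 2 days; on this read-out lower numbers stand for stronger inhibition and higher numbers for weaker inhibition. In this assay compound 1 gives 29000 nM and compound 2 gives 4600 nM. The two differ in one place, (bromo in place of isopropyl on an aromatic carbon), and that change made a 6.3-fold lower number from compound 1 to compound 2 (0.80 log units; beyond the scatter).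

Compound 3 has the same atoms as compound 1 joined differently; the difference between the two cores is not broken down here. In this assay compound 3 gives only a limit of the assay, > 200000 nM. This is the limit of > 200000 nM in this assay, at which 1 of the 3 values shown sits.

Compound 4 `O=c1[nH]c(=O)n([C@H]2C[C@H](O)[C@@H](CO)O2)cc1-c1cnnn1-c1ccc(Br)cc1` is not yet measured. It stands to compound 3 as compound 2 stands to compound 1: the change is bromo in place of isopropyl on an aromatic carbon, at a place described in the same words as before, so it is the same change. On the core of compound 1 it brought a 6.3-fold lower number from compound 1 to compound 2 (0.80 log units; beyond the scatter). If it carries over to the core of compound 3, the value of compound 4 is expected to come down from the limit of compound 3 by a comparable step, an at least 2.5-fold lower number from compound 3 to compound 4 (0.39 log units; beyond the scatter), though since compound 3 gave only > 200000 nM the starting point is itself open. Compound 4 is therefore estimated at 80000 nM, with a likely range from 20000 nM to 300000 nM, and a real chance that the assay again reports only a limit.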

Compound 4, half-maximal inhibitory concentration: 61000 nM
For compound 4 the middle estimate is 1.3-fold (0.12 log units) above the measured one; the range from low to high includes it.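

In this assay, bromo in place of isopropyl on the core of compound 3 gave an at least 3.2-fold lower number from compound 3 to compound 4 (0.51 log units; beyond the scatter), so the change lowered the number in the same direction on both isomeric cores, and on each core the step lies beyond the scatter. This shows that the direction of the change carried over from one core to the other, but it does not show that the size carried over, and the two steps can only be set side by side with that reservation: the same change on two cores in this assay, a 6.3-fold lower number (0.80 log units; beyond the scatter) from compound 1 to compound 2 and an at least 3.2-fold lower number (0.51 log units; beyond the scatter) from compound 3 to compound 4; the limit leaves it open whether they differ. Compound 3 gives > 200000 nM, which is a limit of the assay and not a number, so the step built on it has a floor but no upper end, and the whole comparison rests on just two cores and one pair of groups.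

The compounds shown leave open whether the same direction would hold on both cores for other groups on the aromatic carbon of the 4-isopropylphenyl and 4-bromophenyl rings, such as an amine, a carboxylic acid or a longer chain. They also leave open whether a group other than bromo would bring the core of compound 3 closer to the values seen on the core of compound 1.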